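Urea tail variation in the triarylethylene series

A few compounds are considered here, and "the series" means these few. Any claim that something is new, unique, unknown or untested is made for them only; others in the source may bear on it.

Among the compounds with values here, compound 2 `COc1ccc(/C(=C(/CCNC(=O)NC2CCCCC2)c2ccccc2)c2ccccc2)cc1` gives 37200 nM in a functional assay on MCF7 cells (Homo sapiens) for cytotoxicity, read by MTT assay, with a stated time of 72 h (a lower number here means a stronger inhibitor, a higher number a weaker inhibitor), and is the only member of the set with a number rather than a limit. Compound 1 `COc1ccc(/C(=C(/CCNC(=O)NCc2ccccc2)c2ccccc2)c2ccccc2)cc1` reaches only a limit in this assay, > 50000 nM. Within the data shown here, the single measured step, an at least 1.3-fold lower number from compound 1 to compound 2 (0.12 log units; that floor lies within the scatter), rests on that limit of > 50000 nM in this assay, at which 1 of the 2 values shown sits, and gives little guidance. Compound 3 `COc1ccc(/C(=C(/CCNC(=O)N2CCOCC2)c2ccccc2)c2ccccc2)cc1` carries the change (morpholin-4-yl in place of cyclohexylamino on a carbonyl carbon). Among the measured compounds shown here, no measured step covers this change, so the expected step is a 1.1-fold higher number from compound 2 to compound 3 (0.03 log units; within the scatter), not beyond the scatter. Compound 3 is therefore estimated at 40000 nM, from 15000 nM to 100000 nM.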

Compound 3, half-maximal inhibitory concentration: > 50000 nM
Compound 3 was reported as a limit; the forecaster's own chance of this, stated with the estimate: 45%; middle value at least 1.2-fold (0.09 log units) away from the limit.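

Removing the hydrogen-bond donor of cyclohexylamino and adding the ring oxygen of morpholin-4-yl on this carbonyl carbon does not yield a measurable number: in this assay, compound 3 gives > 50000 nM, which is a limit. As far as these compounds go, the change gives an at least 1.3-fold higher number from compound 2 to compound 3 (0.12 log units; that floor lies within the scatter), so it brings no gain in this assay, and the true size of the step stays unknown. The step between the two limit compounds cannot be read, and the set now sits mostly at one end: the limit of > 50000 nM in this assay, at which 2 of the 3 values shown sit.

Open, from the compounds shown here alone, is whether a piperazin-1-yl group, a dimethylamino group or a carboxylic acid in the urea tail would give a number clear of this limit.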